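The compounds below may be only part of what the source reports. "The series", "measured", "known", "first", "only" and "open" are said of these compounds alone.

Three compounds, all measured in an assay on NIH3T3 cells with Urotensin-2 receptor (Homo sapiens) as the target (on this read-out higher numbers stand for larger maximal responses and lower numbers for smaller maximal responses), share a carbamate or urea link to a substituted phenyl ring and a chlorophenyl-bearing side chain with a dimethylamino group. Compound 1, `CN(C)CCC(OC(=O)Nc1ccc(Oc2ccccc2)cc1)c1ccc(Cl)cc1`, gives 107%. Compound 2, `CN(C)CCC(OC(=O)Nc1ccc(C(C)(C)C)cc1)c1ccc(Cl)cc1`, carries tert-butyl in place of phenoxy on an aromatic carbon and gives 105%; the change made a number 2 percentage points lower from compound 1 to compound 2 (within the scatter). Compound 3, `CN(C)CCC(NC(=O)Nc1ccc(Oc2ccccc2)cc1)c1ccc(Cl)cc1`, gives 108%. The difference between the core of compound 1 and the core of compound 3 is not broken down here; their values lie within the usual scatter of one another, as do all three numbers shown.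

Compound 4, `CN(C)CCC(NC(=O)Nc1ccc(C(C)(C)C)cc1)c1ccc(Cl)cc1`, has not yet been measured. From compound 3 it differs by tert-butyl in place of phenoxy on an aromatic carbon, the same change as that from compound 1 to compound 2, made at the same place. Because a number 2 percentage points lower from compound 1 to compound 2 (within the scatter) gave no real movement, compound 4 is expected to behave much like compound 3, with an estimated step of a number 2 percentage points lower from compound 3 to compound 4 (within the scatter) in this assay. The expected value for compound 4 in this assay is 106%, most likely between 96% and 116%.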

Compound 4, largest response reached (reported as efficacy), in percent of the reference or control that the assay uses: 103%
Beside the measured number, compound 4's estimate is 3 percentage points above it, and the stated range covers the measured number.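

In this assay, putting tert-butyl in place of phenoxy on the core of compound 3 gives a number 5 percentage points lower from compound 3 to compound 4 (within the scatter), and this step can be set beside the one already seen on the other core: the same change on two cores in this assay, a number 2 percentage points lower (within the scatter) from compound 1 to compound 2 and a number 5 percentage points lower (within the scatter) from compound 3 to compound 4, 3 percentage points apart, within the scatter of two such steps. On these two cores, then, the change carries over with no detectable difference, whether the link is the carbamate of compound 1 or the urea of compound 3, and in neither case does it move the maximal response beyond the scatter. This does not show that the change would behave the same way on any further core, and two steps this small cannot reveal a slight difference between the two cores, nor do they say anything about a read-out other than maximal response.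

The compounds shown leave open what other groups would do at this place, such as an amine, a carboxylic acid or a longer chain. They also leave open what would happen if the dimethylamino group or the chlorine of the side chain were replaced.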